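Leaving the 2-methoxyphenyl urea series: compound 4

The source may report more compounds than this note shows. Statements on the series, on what has been measured and on what is new or still open speak of the compounds shown alone.

Values in a functional assay on A549 cells (Homo sapiens) for antiproliferative activity, read by MTT assay; a lower number here means a stronger inhibitor, a higher number a weaker inhibitor:
- compound 1 `COc1cc2c(Oc3ccc(NC(=O)Nc4ccccc4)cc3)ccnc2cc1OCCCCCCC(=O)NO`: 1650 nM
- compound 2 `COc1cc2c(Oc3ccc(NC(=O)NC4CCCCC4)cc3)ccnc2cc1OCCCCCCC(=O)NO`: 850 nM
- compound 3 `COc1ccccc1NC(=O)Nc1ccc(Oc2ccnc3cc(OCCCCCCC(=O)NO)c(OC)cc23)cc1`: 16200 nM

Compound 3 has the highest number of the three. Next is compound 4 `COc1cc2c(Oc3ccc(NC(=O)N/N=C/c4ccc(F)cc4)cc3)ccnc2cc1OCCCCCCC(=O)NO`, with this change on the amide-type nitrogen: a group of 9 heavy atoms (7 carbon, 1 nitrogen, 1 fluorine; one six-membered aromatic ring of carbon only) in place of a group of 8 heavy atoms (7 carbon, 1 oxygen; one six-membered aromatic ring of carbon only), on an amide-type nitrogen. Within the data shown here, two measured steps bear on it: a 9.8-fold higher number from compound 1 to compound 3 (0.99 log units; beyond the scatter) and a 19-fold higher number from compound 2 to compound 3 (1.28 log units; beyond the scatter). Against these stands a 1.9-fold lower number from compound 1 to compound 2 (0.29 log units; within the scatter). Compound 4 no longer carries the 2-methoxyphenyl, so a modest step to a lower number is expected. Among the measured compounds shown here, no measured compound carries the entering group, so the range stays wide. The expected change is a 6.5-fold lower number from compound 3 to compound 4 (0.81 log units; beyond the scatter). For compound 4 the estimated value is 2500 nM, with an expected range of 700 nM to 10000 nM.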

Compound 4, half-maximal inhibitory concentration: 4920 nM
Compound 4: middle estimate off by 2.0-fold (0.29 log units), on the low side; low and high end bracket the measured number.
By their numbers in this assay, from the lowest: compounds 2 and 1 (each within the scatter of the next); then compound 4; then compound 3.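

In this assay, replacing the 2-methoxyphenyl on this amide-type nitrogen with the fluorine- and nitrogen-bearing group recovers part of the loss, with a 3.3-fold lower number from compound 3 to compound 4 (0.52 log units; beyond the scatter) as the step. The new group still falls short of both plain rings, with a 3.0-fold higher number from compound 1 to compound 4 (0.47 log units; beyond the scatter) for phenyl and a 5.8-fold higher number from compound 2 to compound 4 (0.76 log units; beyond the scatter) for cyclohexyl, so a group with a non-aromatic double bond does not match them here. No supporting evidence is available to account for this order.

Still open, from the compounds shown here alone, is which part of the entering group, the fluorine, the added nitrogen or the double bond, sets its value, and how a benzyl or methyl group would compare on this nitrogen.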